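Three Aryl Sulfonamides Sitting at the Assay Ceiling

This account rests on a few compounds, and the source may have more. Where it says the series, first, only, none or still open, it means among the compounds named here.

Three close relatives share one core and differ only in the aryl group on the sulfonyl sulfur: compound 1 `Cc1ccc(S(=O)(=O)NC2=NCCN2C(=S)SN2CCn3c2nsc3=S)cc1`, compound 2 `O=S(=O)(NC1=NCCN1C(=S)SN1CCn2c1nsc2=S)c1ccccc1Cl` and compound 3 `O=S(=O)(NC1=NCCN1C(=S)SN1CCn2c1nsc2=S)c1ccc(Cl)cc1Cl`. In a functional assay on KYSE-510 cells (Homo sapiens) for antiproliferative activity, read by crystal violet staining, with a stated time of 96 h (a higher number here means a weaker inhibitor of growth, a lower number a stronger inhibitor of growth), compound 1 gives >= 20000 nM, which is a limit of the assay rather than a measured number. Compound 2 likewise gives >= 20000 nM, again a limit. Compound 3 gives >= 20000 nM, also a limit. Because all three values sit at the limit of >= 20000 nM in this assay, at which 3 of the 3 values shown sit, the steps a step that the two limits leave unreadable from compound 1 to compound 2, a step that the two limits leave unreadable from compound 1 to compound 3 and a step that the two limits leave unreadable from compound 2 to compound 3 cannot be read for size or direction. Compound 4 `O=S(=O)(NC1=NCCN1C(=S)SN1CCn2c1nsc2=S)c1ccc(F)c(Cl)c1` has not yet been measured; it differs from compound 1 by 3-chloro-4-fluorophenyl in place of 4-methylphenyl on a sulfonyl sulfur. Among the compounds with values here, the steps that bear on this change are the three unreadable ones, which show no shift beyond the scatter but also cannot exclude one. Compound 4 is therefore expected to stay at the limit, with an estimate of 20000 nM and a range from 10000 nM to 40000 nM. That estimate corresponds to an expected step of a number no higher from compound 1 to compound 4 (the limit leaves the size open).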

Compound 4, concentration for 50% growth inhibition: >= 20000 nM
Compound 4: no number, only a limit (the forecaster's own chance of this, stated with the estimate: 85%); the middle value sits exactly at the limit.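

The steps from compound 1, compound 2 and compound 3 to compound 4 cannot be read for size or direction, because all four values are limits: the limit of >= 20000 nM in this assay, at which 4 of the 4 values shown sit. The compounds shown leave open how strongly any of them inhibits growth, and whether changing the aryl group on the sulfonyl sulfur shifts that inhibition at all.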